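Nitrofuran amides on Vero cells: from chloro to tert-butyl

A few compounds are considered here, and "the series" means these few. Any claim that something is new, unique, unknown or untested is made for them only; others in the source may bear on it.

Measured so far:
- compound 1 `O=C(NCc1ccccc1Cl)c1ccc([N+](=O)[O-])o1`, in an ADME assay on Vero cells (Chlorocebus sabaeus) for cytotoxicity, read by MTT assay, with a stated time of 48 h (a lower number here means that less compound is tolerated, a higher number that more compound is tolerated), compound 1 gives 11000 nM
- compound 2 `CC(C)(NC(=O)c1ccc([N+](=O)[O-])o1)c1ccc(Cl)cc1`, in this assay compound 2 gives 81000 nM

Two amides sharing the same nitrofuran carboxamide core have been run in this assay. Within the data shown here, compound 2 stands at the higher of the two numbers; the only comparison available is compound 1, whose number is lower, and that gap lies beyond the usual scatter. Among the measured compounds shown here, the two compounds differ in more than one place, so their pair gives no clean single-change step to lean on.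

The next compound, compound 3 `CC(C)(C)c1ccc(C(C)(C)NC(=O)c2ccc([N+](=O)[O-])o2)cc1`, changes compound 2 in exactly one place: tert-butyl in place of chloro on an aromatic carbon. For the measured compounds named here, no measured pair shows this kind of change, so there is nothing in the data that fixes its size or direction. The expectation for compound 3 is therefore cautious: a small step downward from compound 2 that may well stay within the scatter, so that a 1.6-fold lower number from compound 2 to compound 3 (0.21 log units; within the scatter) is what is estimated. On that basis compound 3 is expected to give 50000 nM, with a plausible range from 15000 nM to 150000 nM.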

Compound 3, half-maximal cytotoxic concentration: > 150000 nM
Compound 3: a limit, no number (the forecaster's own chance of this, stated with the estimate: 15%); at least 3.0-fold (0.47 log units) between middle value and limit.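

Among these compounds, at this position, on an aromatic carbon para to a large group, the earlier compounds gave no single-change step; in this assay, tert-butyl in place of chloro now gives an at least 1.8-fold higher number from compound 2 to compound 3 (0.26 log units; that floor lies within the scatter). That size is only a floor, and because the floor itself lies within the scatter, the step shows a direction that the data do not yet tie to any firm size, only that tert-butyl here does not bring the lower number that a step from this starting point might have given. Compound 3 stands at a limit of the assay and not at a number: the limit of > 150000 nM in this assay, at which 1 of the 3 values shown sits.

The compounds shown leave open how far beyond that limit compound 3 lies, and so how large the step from chloro to tert-butyl really is. They also leave open what other groups would give at this same position, such as an amine, a carboxylic acid or a longer chain, and whether tert-butyl in place of chloro would give a similar step on the amide of compound 1.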